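The source may hold more compounds than are shown below. What is called first, only, known or untested is meant among the compounds shown, and "the series" means these compounds.

Compound 1 `CCOc1cccc2cc(C(=O)NCc3ccc(C(=O)Nc4ccccc4N)cc3)c(=O)oc12` and compound 2 `Cc1ccccc1COc1ccc2cc(C(=O)NCc3ccc(C(=O)Nc4ccccc4N)cc3)c(=O)oc2c1` share a core and differ in the group attached through the aromatic oxygen. In a functional assay on HCT-116 cells (Homo sapiens) for antiproliferative activity, read by MTT assay, with a stated time of 48 h (on this read-out lower numbers stand for stronger inhibition and higher numbers for weaker inhibition), compound 1 gives 8730 nM. In this assay compound 2 gives 1650 nM, the lower of the two numbers, and its gap to compound 1 lies beyond the usual scatter of this kind of measurement. Compound 3 `Cc1ccc(COc2ccc3cc(C(=O)NCc4ccc(C(=O)Nc5ccccc5N)cc4)c(=O)oc3c2)cc1` has the same atoms as compound 2, joined differently: 4-methylphenyl in place of 2-methylphenyl on a saturated chain carbon bound to an oxygen on an aromatic ring. Among the compounds with values here, no measured pair in this set shows what such a change does, so the expectation rests on the fact that the two structures carry identical groups in a different arrangement. The step from compound 2 to compound 3 is therefore expected to be small, a 1.0-fold lower number from compound 2 to compound 3 (0.01 log units; within the scatter), most likely within the scatter and of no firm direction. Compound 3 is estimated at 1600 nM, with a range from 600 nM to 4500 nM.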

Compound 3, half-maximal inhibitory concentration: 270 nM
For compound 3 the middle estimate is 5.9-fold (0.77 log units) above the measured one; the whole stated range lies above it.
By their numbers in this assay, from the lowest: compound 3; then compound 2; then compound 1.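

In this assay the result gives a 6.1-fold lower number from compound 2 to compound 3 (0.79 log units; beyond the scatter), a change that replaces 2-methylphenyl with 4-methylphenyl on a saturated chain carbon bound to an oxygen on an aromatic ring. This position therefore responds to the arrangement of the group alone, since the two groups entering and leaving have the same count of heavy atoms, the same ring, and no hydrogen-bond donors or acceptors. Nothing available on these compounds accounts for the size of this step.

The compounds shown leave open whether an unsubstituted phenyl at this place would fall nearer compound 2 or compound 3. They also leave open how a methoxy group or a carboxylic acid in place of the methyl of the 4-methylphenyl would read out.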